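Adding One More Carbon to an Alkenyl Chain

The source may report more compounds than this note shows. Statements on the series, on what has been measured and on what is new or still open speak of the compounds shown alone.

Compound 1 `C=CCCCCOc1ccccc1-c1cnc(OCCCC=C)n1C` and compound 2 `C=CCCCCOc1ccccc1-c1cnc(OCCCCC=C)n1C` share a core and differ only in the length of one alkenyl chain. In a functional assay on MCF7 cells (Homo sapiens) for inhibition, read by colorimetric assay and MTT assay, with a stated time of 72 h (a lower number here means a stronger inhibitor, a higher number a weaker inhibitor), compound 1 gives 7000 nM and compound 2 gives 5000 nM. Going by the values given here, these two values cannot be told apart, so compound 2 stands level with its only measured neighbour. Compound 3 `C=CCCCCCOc1ncc(-c2ccccc2OCCCCC=C)n1C` lengthens the same chain again, from pent-4-en-1-yl to hex-5-en-1-yl: allyl in place of vinyl on a saturated chain carbon, four bonds along the chain from an oxygen on an aromatic ring. This places allyl in place of vinyl on a saturated chain carbon, four bonds along the chain from an oxygen on an aromatic ring. Among the compounds with values here, the one measured step that bears on it is the matching change three bonds along, a 1.4-fold lower number from compound 1 to compound 2 (0.15 log units; within the scatter). A single small step shows no trend, so no change beyond the scatter is expected in this assay. The expected step is a 1.1-fold lower number from compound 2 to compound 3 (0.05 log units; within the scatter). Compound 3 is estimated at 4500 nM, with an expected range of 2000 nM to 10000 nM.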

Compound 3, half-maximal inhibitory concentration: 63000 nM
Compound 3: the middle estimate sits 14-fold (1.15 log units) below what was measured, outside the stated range (above it).
By their numbers in this assay, from the lowest: compounds 2 and 1 (each within the scatter of the next); then compound 3.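

In this assay, the same kind of lengthening that made no readable difference one step earlier now gives a 13-fold higher number from compound 2 to compound 3 (1.10 log units; beyond the scatter), so this chain tolerates extension only up to a point, and the change of allyl in place of vinyl at this place is not neutral. The loss also appears against the shorter chain, with a 9.0-fold higher number from compound 1 to compound 3 (0.95 log units; beyond the scatter), which is beyond the scatter as well. Nothing in the available data explains why the number jumps at this length.

The compounds shown leave open whether a still longer chain would raise the number further or whether the effect levels off. They also leave open whether the terminal double bond matters, a question that a fully saturated chain or a chain ending in an amine could address.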